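The source may report more compounds than this note shows. Statements on the series, on what has been measured and on what is new or still open speak of the compounds shown alone.

Measured compounds:
compound 1 `CCN(CC#CC#CC(C)(C)OC)Cc1cccc(OC[Si](C)(C)c2ccccc2C)c1`, 70 nM in a functional assay on liver (Sus scrofa) for inhibition of squalene monooxygenase (Homo sapiens), using microsomes; on this read-out lower numbers stand for stronger inhibition and higher numbers for weaker inhibition
compound 2 `CCN(C/C=C/C#CC(C)(C)C)Cc1cccc(OC[Si](C)(C)c2ccc(F)cc2)c1`, 60 nM
compound 3 `CCN(C/C=C/C#CC(C)(C)C)Cc1cccc(OC[Si](C)(C)c2ccc(Cl)cc2)c1`, 400 nM

Compound 2 gives the lowest number of the three; compound 1 sits within the scatter of it, compound 3 clearly higher.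

Compound 4 `CCN(C/C=C/C#CC(C)(C)C)Cc1cccc(OC[Si](C)(C)c2ccc(Br)cc2)c1` differs from compound 2 by bromo in place of fluoro on an aromatic carbon. Among the compounds with values here, the only measured step that bears on this is the halogen swap at the same place, a 6.7-fold higher number from compound 2 to compound 3 (0.82 log units; beyond the scatter). Bromo in place of fluoro is the same kind of exchange, and a step of similar size toward a higher number is therefore expected in this assay, that is an 8.3-fold higher number from compound 2 to compound 4 (0.92 log units; beyond the scatter). For compound 4 the expected value is 500 nM, with a range from 150 nM to 1500 nM.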

Compound 4, half-maximal inhibitory concentration: 210 nM
The estimate for compound 4 lay 2.4-fold (0.38 log units) above the measured number, and the stated range covers the measured number.
By their numbers in this assay, from the lowest: compounds 2 and 1 (each within the scatter of the next); then compounds 4 and 3 (each within the scatter of the next).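

Relative to 4-fluorophenyl, 4-bromophenyl in this assay also gives a 3.5-fold higher number from compound 2 to compound 4 (0.54 log units; beyond the scatter) and so the rise seen with chloro is not confined to one halogen. Chloro and bromo are not separated at this place: a 1.9-fold lower number from compound 3 to compound 4 (0.28 log units; within the scatter) lies within the scatter. Nothing measured here accounts for the gap between fluoro and the two larger halogens.

Open, as far as these compounds go, is whether hydrogen, methoxy or a nitrile on this aromatic carbon would sit with fluoro or with chloro and bromo. Also open, from the compounds shown here alone, is whether the halogen steps carry over to the methoxy-bearing chain of compound 1.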